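The compounds below may be only part of what the source reports. "The series", "measured", "known", "first", "only" and "open" are said of these compounds alone.

In an ADME assay on CEM-SS cells (Homo sapiens) for cytotoxicity, read by XTT assay, with a stated time of 6 days (a higher number here means that more compound is tolerated, a lower number that less compound is tolerated), compound 3 `CCCC(=O)OCSc1ccccc1C(=O)NCC(=O)NC` reads > 100 uM, which is a limit and not a number. Compound 1 `CCCC(=O)OCSc1ccccc1C(=O)NCCC(N)=O` reads > 100 uM, which is also a limit. Among the compounds with values here, the only measured step, a step that the two limits leave unreadable from compound 1 to compound 3, therefore gives no usable size. Compound 2 `CCCC(=O)OCSc1ccccc1C(=O)N[C@H]1CCC[C@@H]1C(N)=O` gives 31.2 uM; 43.3 uM (2 entries), the only true numbers among these compounds. Within the data shown here, compound 4 `CCCC(=O)OCSc1ccccc1C(=O)NCC(=O)NC(C)(C)C` carries tert-butyl in place of methyl on an amide-type nitrogen, and no measured step covers this change. Compound 2 at 31.2 uM; 43.3 uM (2 entries) shows that a measurable number can occur in this small set, so a modest fall is possible. The expected step is an at least 1.2-fold lower number from compound 3 to compound 4 (0.09 log units; that floor lies within the scatter), toward less compound tolerated or within the scatter. Compound 4 is estimated at 80 uM, with an expected range from 30 uM to 200 uM.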

Compound 4, half-maximal toxic concentration: 46.8 uM
Estimate against measurement, compound 4: 1.7-fold (0.23 log units) above; the range from low to high includes it.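

In this assay, within the data shown here, tert-butyl in place of methyl on an amide-type nitrogen gives the first step of readable size at this position: an at least 2.1-fold lower number from compound 3 to compound 4 (0.32 log units; beyond the scatter). The change from carbamoylmethyl to (tert-butyl)carbamoyl gives an at least 2.1-fold lower number from compound 1 to compound 4 (0.32 log units; beyond the scatter). Both steps start from a limit, so each is a floor and not a full size.

Only methyl and tert-butyl are shown on this nitrogen, so it remains open whether ethyl or isopropyl there would give a smaller step. A carboxylic acid in place of the amide also remains untested in the compounds shown.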